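The compounds below may be only part of what the source reports. "The series", "measured", "known", "first", "only" and "open" are said of these compounds alone.

Measured in a functional assay on HT-29 cells (Homo sapiens) for inhibition, read by sulforhodamine B assay, with a stated time of 72 h; on this read-out higher numbers stand for weaker inhibition and lower numbers for stronger inhibition:
- compound 1 `C#Cc1cccc(Nc2ncnc3cc(OCCCCCn4ccnc4[N+](=O)[O-])c(OC)cc23)c1`: 280 nM
- compound 2 `COc1cc2c(Nc3cccc(Br)c3)ncnc2cc1OCCCn1ccnc1[N+](=O)[O-]`: 2820 nM
- compound 3 `COc1cc2c(Nc3cccc(Br)c3)ncnc2cc1OCCCCn1ccnc1[N+](=O)[O-]`: 1430 nM

In this assay, compound 3 at 1430 nM lies within the scatter of compound 2, while compound 1 lies beyond the scatter on the lower side.

The next compound is compound 4 `COc1cc2c(Nc3cccc(Br)c3)ncnc2cc1OCCCCCn1ccnc1[N+](=O)[O-]`, which differs from compound 3 in the chain alone: (2-nitro-1H-imidazol-1-yl)methyl in place of 2-nitro-1H-imidazol-1-yl on a saturated chain carbon, four bonds along the chain from an oxygen on an aromatic ring. The change is (2-nitro-1H-imidazol-1-yl)methyl in place of 2-nitro-1H-imidazol-1-yl on a saturated chain carbon, four bonds along the chain from an oxygen on an aromatic ring.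

For the measured compounds named here, only one measured step bears directly on this: the same replacement three bonds along the chain, a 2.0-fold lower number from compound 2 to compound 3 (0.29 log units; within the scatter). That is a single step and it stays within the scatter, so it sets no firm trend. Compound 1 differs from compound 3 in more than one place, so it gives no clean size for this change.

On that basis, a step of similar or smaller size is expected in this assay, leaning towards a lower number, with none expected beyond the scatter. The expected step is a 1.4-fold lower number from compound 3 to compound 4 (0.16 log units; within the scatter). For compound 4 the estimated value is 1000 nM, with an expected range of 400 nM to 2500 nM.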

Compound 4, half-maximal inhibitory concentration: 2540 nM
The estimate for compound 4 lay 2.5-fold (0.40 log units) below the measured number; measured number outside the range, above it.
By their numbers in this assay, from the lowest: compound 1; then compounds 3, 4 and 2 (each within the scatter of the next).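

In this assay, the added chain length on the bromo series gives no trend: a 1.8-fold higher number from compound 3 to compound 4 (0.25 log units; within the scatter) stays inside the usual scatter, as does the end-to-end comparison, a 1.1-fold lower number from compound 2 to compound 4 (0.05 log units; within the scatter), so the three chain lengths of compound 2, compound 3 and compound 4 cannot be told apart on this read-out. The single step beyond the scatter is the first clean comparison at the aromatic substituent, with the chain held constant: a 9.1-fold higher number from compound 1 to compound 4 (0.96 log units; beyond the scatter), for bromo in place of ethynyl, so among the compounds shown the clear difference comes from that substituent and not from the chain. No supporting evidence is available to explain either the flat chain steps or the ethynyl and bromo difference.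

Going by these compounds, whether ethynyl in place of bromo gives a step of similar size on the chains of compound 2 and compound 3 remains open, as does the response to a longer chain than that of compound 4. Also open, on these data alone, is what happens when an amine or a carboxylic acid takes the place of the 2-nitro-1H-imidazol-1-yl group at the chain end.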